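This account rests on a few compounds, and the source may have more. Where it says the series, first, only, none or still open, it means among the compounds named here.

Working notes on the series, step from compound 2 to compound 3.

Compound 1 `O=C1C(NC2CC2)=CC(=O)c2c1nc1n2[C@H]2OC[C@@H](O)[C@H]2OC1` carries a cyclopropyl on the amine nitrogen. In a functional assay on HeLa cells (Homo sapiens) for inhibition, read by sulforhodamine B assay (on this read-out lower numbers stand for stronger inhibition and higher numbers for weaker inhibition), compound 1 gives > 16000 nM, which is a limit of the assay and not a number. Compound 2 `O=C1C(NC2CCCC2)=CC(=O)c2c1nc1n2[C@H]2OC[C@@H](O)[C@H]2OC1` carries a cyclopentyl at the same place. In this assay compound 2 gives > 16000 nM, again a limit rather than a number. Within the data shown here, the only measured step, a step that the two limits leave unreadable from compound 1 to compound 2, therefore cannot be read in size, since both values sit at the limit of > 16000 nM in this assay, at which 2 of the 2 values shown sit. Compound 2 thus stands at the limit, with no numerical placing among the compounds shown.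

Compound 3 `Cc1ccc(NC2=CC(=O)c3c(nc4n3[C@H]3OC[C@@H](O)[C@H]3OC4)C2=O)cc1` differs from compound 2 by 4-methylphenyl in place of cyclopentyl on an amine nitrogen. Among the measured compounds shown here, no measured step involves an aromatic group on this nitrogen, so the cyclopropyl-to-cyclopentyl step gives no readable guide; it only shows that two cycloalkyl groups both leave compound 2 and compound 1 at the limit. The step of a number no higher from compound 2 to compound 3 (the limit leaves the size open) is therefore expected to be small or not resolvable. For compound 3 the expected value in this assay is 16000 nM, within a range from 4000 nM to 60000 nM, most likely reported again only as a limit.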

Compound 3, half-maximal inhibitory concentration: 6590 nM
Estimate against measurement, compound 3: 2.4-fold (0.39 log units) above; low and high end bracket the measured number.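

In this assay, compound 3 is the only compound shown that gives a number rather than a limit, so an amine nitrogen carrying 4-methylphenyl can bring this series into the readable range, which neither cycloalkyl group shown does. Exchanging a cycloalkyl group for this aromatic ring comes with an at least 2.4-fold lower number from compound 2 to compound 3 (0.38 log units; beyond the scatter), and the same holds against the smaller ring, with an at least 2.4-fold lower number from compound 1 to compound 3 (0.38 log units; beyond the scatter). Both steps are bounded on one side only, and their full size stays unknown, as does any difference between cyclopropyl and cyclopentyl: the limit of > 16000 nM in this assay, at which 2 of the 3 values shown sit.

The compounds shown leave open whether the step belongs to the aromatic ring itself or to its methyl group; a plain phenyl, a 4-chlorophenyl or a 4-methoxyphenyl on the same nitrogen would separate the two. Also open, on these data alone, is whether the aromatic ring must sit directly on the nitrogen, which a benzyl group there would test, and whether an open alkyl chain at this place stays at the limit as the two cycloalkyl groups do.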